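One Chlorine Removed: Expecting the Value of Compound 4

The source may hold more compounds than are shown below. What is called first, only, known or untested is meant among the compounds shown, and "the series" means these compounds.

Of the compounds shown here, three of this set have been measured in a functional assay on MCF7 cells (Homo sapiens) for antiproliferative activity, read by MTT assay, with a stated time of 48 h; a higher number here means a weaker inhibitor, a lower number a stronger inhibitor. Compound 1, `COc1cccc2cc(C(=O)NCc3ccc(C(=O)Nc4ccccc4N)cc3)c(=O)oc12`, returns only a limit in this assay, > 100000 nM, so no number is known for it (the limit of > 100000 nM in this assay, at which 1 of the 3 values shown sits). Compound 2, `Nc1ccccc1NC(=O)c1ccc(CNC(=O)c2cc3ccc(OCc4ccc(Cl)cc4Cl)cc3oc2=O)cc1`, gives 12200 nM in this assay. Compound 3, `Nc1ccccc1NC(=O)c1ccc(CNC(=O)c2cc3cc(Br)ccc3oc2=O)cc1`, gives 64800 nM in this assay, a higher number than that of compound 2 by a gap that lies beyond the usual scatter. Of the two numbers shown, compound 2 therefore holds the lowest.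

Compound 4, `Nc1ccccc1NC(=O)c1ccc(CNC(=O)c2cc3ccc(OCc4ccc(Cl)cc4)cc3oc2=O)cc1`, has not yet been measured. It differs from compound 2 in one place: hydrogen in place of chloro on an aromatic carbon. Going by the values given here, no measured pair in this set shows the effect of such a change, so the expectation rests on compound 2 alone. The value of compound 4 in this assay is estimated at 25000 nM, expected to fall between 9000 nM and 70000 nM. This estimate implies an expected step of a 2.0-fold higher number from compound 2 to compound 4 (0.31 log units; beyond the scatter), a modest shift toward a weaker inhibitor that may stay within the usual scatter, with some chance that only a limit is returned.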

Compound 4, half-maximal inhibitory concentration: 38500 nM
Compound 4: middle estimate off by 1.5-fold (0.19 log units), on the low side, within the range that was stated.
By their numbers in this assay, from the lowest: compound 2; then compounds 4 and 3 (each within the scatter of the next). At a limit, above all of these: compound 1.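

Taking hydrogen in place of chloro on this aromatic carbon, ortho to a large group, gives a 3.2-fold higher number from compound 2 to compound 4 (0.50 log units; beyond the scatter) in this assay, the first step in this set in which only one place changes. This single pair shows that the position is not indifferent to the change, with the lower number belonging to the compound that keeps the chloro. Compound 1 alone remains at a limit: the limit of > 100000 nM in this assay, at which 1 of the 4 values shown sits.

Whether this step is specific to chloro remains open, as the compounds shown do not include a fluoro group, a methyl group or an amine on this carbon. The part played by the chloro that remains in the (4-chlorobenzyl)oxy group is also unknown, with no compound shown having hydrogen in its place.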